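A few compounds are considered here, and "the series" means these few. Any claim that something is new, unique, unknown or untested is made for them only; others in the source may bear on it.

Within the data shown here, compound 1 `C=CCOc1c(C)c(C)c2c(c1C)CCC(C)(COc1ccc(/C=C3\SC(=O)NC3=O)cc1Br)O2` gives 102% in a functional assay on MCF7 cells (Homo sapiens), tested at 2.5 uM (a lower number here means a stronger effect, a higher number a weaker effect of the compound at the concentration tested), the highest of the three numbers measured so far. Compound 2 `CC(C)=CCOc1c(C)c(C)c2c(c1C)CCC(C)(COc1ccc(/C=C3\SC(=O)NC3=O)cc1C)O2` gives 89% and compound 3 `CC(C)=CCOc1c(C)c(C)c2c(c1C)CCC(C)(COc1ccc(/C=C3\SC(=O)NC3=O)cc1-c1ccc(F)cc1)O2` gives 87%; both stand beyond the scatter below compound 1. Among the measured compounds shown here, the single step measured between compounds differing in one place, a number 2 percentage points lower from compound 2 to compound 3 (within the scatter), concerns another position and does not bear on the change at hand. Compound 4 `C=CCOc1c(C)c(C)c2c(c1C)CCC(C)(COc1ccc(/C=C3\SC(=O)NC3=O)cc1)O2` differs from compound 1 by hydrogen in place of bromo on an aromatic carbon. For the measured compounds named here, no measured pair shows this change directly, so only the closeness of all three numbers to no effect guides the expectation. Compound 4 is therefore expected to give 95%, between 82% and 108%. The expected step is a number 7 percentage points lower from compound 1 to compound 4 (within the scatter), within the scatter.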

Compound 4, a percentage reported as activity, at one concentration (the size of the read-out at that concentration, not a potency): 45%
For compound 4 the middle estimate is 50 percentage points above the measured one, and the stated range ends above it.
By their numbers in this assay, from the lowest: compound 4; then compounds 3 and 2 (each within the scatter of the next); then compound 1.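

Hydrogen in place of bromo on the aromatic carbon ortho to a large group gives a number 57 percentage points lower from compound 1 to compound 4 (beyond the scatter) in this assay and so shows that this position is not indifferent to what it carries, which the earlier compounds, all close to no effect, could not show. The loss of a single heavy atom is enough for a step of this size. Nothing at hand explains that size. From the compounds shown here alone, whether fluoro, chloro or methoxy at this place would stay near compound 4 or near compound 1 remains open.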